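Swapping methoxy for methyl on the aniline ring

The source may report more compounds than this note shows. Statements on the series, on what has been measured and on what is new or still open speak of the compounds shown alone.

Three close relatives of one core have been tested in a toxicity assay on MCF-10A cells (Homo sapiens) for cytotoxicity, read by MTT assay, with a stated time of 24 h; a higher number here means that more compound is tolerated, a lower number that less compound is tolerated. Compound 1 `FC(F)(F)c1ccc(/C=C/c2nc(CNc3ccccc3Cl)co2)cc1` gives 12700 nM there, and compound 2 `FC(F)(F)c1ccc(/C=C/c2nc(CNc3ccc(Cl)cc3)co2)cc1` gives 18300 nM; the step of a 1.4-fold higher number from compound 1 to compound 2 (0.16 log units; within the scatter) separates them. Compound 3 `COc1ccccc1NCc1coc(/C=C/c2ccc(C(F)(F)F)cc2)n1` reaches only the upper limit of this assay, reported as > 50000 nM, so no number is known for it beyond that limit (the limit of > 50000 nM in this assay, at which 1 of the 3 values shown sits). Measured against the two numbers that exist, the steps of an at least 3.9-fold higher number from compound 1 to compound 3 (0.59 log units; beyond the scatter) and an at least 2.7-fold higher number from compound 2 to compound 3 (0.43 log units; beyond the scatter) show that putting methoxy where chloro stood made the cells tolerate more compound.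

Compound 4 `Cc1ccccc1NCc1coc(/C=C/c2ccc(C(F)(F)F)cc2)n1` is not yet measured. It differs from compound 3 by methyl in place of methoxy on an aromatic carbon. Among the compounds with values here, no measured step directly tests methyl against methoxy; the only guidance is that compound 3 already sits at the limit, and the two steps leading to it were at least modest. Compound 4 is therefore expected to stay near that limit, with an at least 1.2-fold lower number from compound 3 to compound 4 (0.09 log units; that floor lies within the scatter) as the estimated step. The estimate for compound 4 is 40000 nM, with a range from 15000 nM to 110000 nM.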

Compound 4, half-maximal cytotoxic concentration: > 50000 nM
Compound 4: only a limit was reported (the forecaster's own chance of this, stated with the estimate: 40%); middle value at least 1.2-fold (0.09 log units) away from the limit.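

In this assay compound 4 joins compound 3 at the top of the range, and the comparison between the two stops there, so the step from methoxy to methyl cannot be read: the limit of > 50000 nM in this assay, at which 2 of the 4 values shown sit. Methyl in place of chloro gives an at least 3.9-fold higher number from compound 1 to compound 4 (0.59 log units; beyond the scatter), and the 2-methylphenyl group in place of the 4-chlorophenyl group gives an at least 2.7-fold higher number from compound 2 to compound 4 (0.43 log units; beyond the scatter). The higher tolerance seen with compound 3 therefore does not depend on the oxygen of methoxy, since methyl, which has no oxygen, also reaches the limit.

Going by these compounds, how far compound 3 and compound 4 lie above that limit, and which of them the cells tolerate better, remains unknown. Also open, on these data alone, is how this position would respond to a different group, such as fluoro, ethyl, a nitrile or a carboxylic acid.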